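A few compounds are considered here, and "the series" means these few. Any claim that something is new, unique, unknown or untested is made for them only; others in the source may bear on it.

Compounds measured in a functional assay on SK-BR-3 cells (Homo sapiens) for antiproliferative activity, read by MTT assay, with a stated time of 72 h; a higher number here means a weaker inhibitor, a lower number a stronger inhibitor:
Compound 1 `CCN(CC)CCNc1cc(C)c2cc(NC(=O)c3ccc(Cl)c(Cl)c3)ccc2n1` gives 3710 nM.
Compound 2 `CCc1ccccc1C(=O)Nc1ccc2nc(N3CCN(CC)CC3)cc(C)c2c1` gives 23900 nM.
Compound 3 `Cc1cc(N(C)C)nc2ccc(NC(=O)c3ccc(Cl)c(Cl)c3)cc12` reports only a limit, > 50000 nM.

Among the two numbered results, compound 2 stands highest, with compound 1 the lower of the two. Compound 3 sits at the limit of > 50000 nM in this assay, at which 1 of the 3 values shown sits. Within the data shown here, the only step between measured compounds that differ in one place is an at least 13-fold higher number from compound 1 to compound 3 (1.12 log units; beyond the scatter), a change at the amine end of the shared core.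

Compound 4 `CCN1CCN(c2cc(C)c3cc(NC(=O)c4ccc(F)c(F)c4)ccc3n2)CC1` differs from compound 2 at the other end: 3,4-difluorophenyl in place of 2-ethylphenyl on a carbonyl carbon. Among the measured compounds shown here, no measured pair separates that amide change alone, so the step from compound 1 to compound 3 does not bear on it directly. What the numbers show is that compound 1, which carries a dihalogenated aryl amide together with a different amine, gives a lower number than compound 2; the two changes cannot be separated. A halogenated ring entering for the 2-ethylphenyl group is therefore expected to lower the number in this assay by a moderate step, a 3.0-fold lower number from compound 2 to compound 4 (0.48 log units; beyond the scatter), rather than leave it within the scatter. Compound 4 is estimated at 8000 nM, with a range from 2500 nM to 25000 nM.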

Compound 4, half-maximal inhibitory concentration: 1980 nM
Estimate against measurement, compound 4: 4.0-fold (0.61 log units) above; the whole stated range lies above it.
By their numbers in this assay, from the lowest: compounds 4 and 1 (each within the scatter of the next); then compound 2. At a limit, above all of these: compound 3.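

In this assay, the aryl group on the amide carbonyl now has a measured effect of its own: 3,4-difluorophenyl in place of 2-ethylphenyl on a carbonyl carbon gives a 12-fold lower number from compound 2 to compound 4 (1.08 log units; beyond the scatter), with the rest of the molecule unchanged. Among the earlier compounds, the only step lay at the amine end, and compound 1 and compound 2 differ at both ends, so the contribution of the amide side could not be read from them. This position therefore responds strongly to the group it carries, but nothing measured here says what about the two groups accounts for the step.

The step does not tell whether the loss of the ethyl group or the gain of the two fluorines carries it, and an unsubstituted phenyl or a phenyl with a single fluorine on this carbonyl would divide the two. Also open, as far as these compounds go, is whether the step holds with another amine at the far end, such as the (2-(diethylamino)ethyl)amino group of compound 1, or with a carboxylic acid on the aryl ring.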